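The compounds below may be only part of what the source reports. "The series", "measured", "known", "first", "only" and "open" are said of these compounds alone.

Values in a functional assay for inhibition, with Homo sapiens as the target (a lower number here means a stronger inhibitor, a higher number a weaker inhibitor), for the measured compounds:
compound 1 `Sc1nncc2cncn12` gives > 48000 nM, a limit of the assay.
compound 2 `COCc1ncc2cnnc(S)n12` gives > 48000 nM, a limit of the assay.
compound 3 `Oc1nncc2cncn12` gives > 48000 nM, a limit of the assay.

None of the three values is a number; all sit at the limit of > 48000 nM in this assay, at which 3 of the 3 values shown sit. Compound 2 differs from compound 1 by methoxymethyl in place of hydrogen on an aromatic carbon, and the step is a step that the two limits leave unreadable from compound 1 to compound 2. Compound 3 differs from compound 1 in the core: hydroxy in place of sulfanyl on an aromatic carbon; the step is a step that the two limits leave unreadable from compound 1 to compound 3. Compound 4 `COCc1ncc2cnnc(O)n12` is not yet measured. It differs from compound 3 by methoxymethyl in place of hydrogen on an aromatic carbon, the same change as from compound 1 to compound 2, on a place described in the same words. Because the same change gave a step that the two limits leave unreadable from compound 1 to compound 2 with both end points at the limit of > 48000 nM in this assay, at which 3 of the 3 values shown sit, compound 4 is expected to return only a limit again in this assay as well. For compound 4 the estimate is 100000 nM, with a range from 48000 nM to 400000 nM, meaning an expected step that the limit leaves unreadable from compound 3 to compound 4.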

Compound 4, half-maximal inhibitory concentration: > 48000 nM
Compound 4: a limit, no number (the forecaster's own chance of this, stated with the estimate: 90%); the middle value lies beyond the limit too.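

In this assay compound 4 gives > 48000 nM, a limit and not a number. Among these compounds, no step from compound 3 or compound 2 to compound 4 can be read. The compounds shown leave open how strongly any of them inhibits and what either change does: the limit of > 48000 nM in this assay, at which 4 of the 4 values shown sit.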